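Shortening the alkyne chain by one carbon

The compounds below may be only part of what the source reports. "The series", "measured", "known", "first", "only" and "open" are said of these compounds alone.

Compound 3 `CCCCCC#Cc1cn(C/C=C/CN2C(=O)c3ccccc3C2=O)c(=O)[nH]c1=O` is measured in an ADME assay on WI-38 cells (Homo sapiens) for cytotoxicity, read by MTT assay, with a stated time of 3 days (a lower number here means a stronger inhibitor, a higher number a weaker inhibitor), where compound 3 gives 40000 nM. That is the lowest of the two numbers shown, the other belonging to compound 1 `CCCCCCCCC#Cc1cn(C/C=C\CN2C(=O)c3ccccc3C2=O)c(=O)[nH]c1=O`, which gives 49000 nM; the gap between the two sits within the scatter. Compound 2 `CCCCCc1ccc(C#Cc2cn(C/C=C\CN3C(=O)c4ccccc4C3=O)c(=O)[nH]c2=O)cc1` reports only a limit, > 100000 nM. Among the measured compounds shown here, the single measured step, an at least 2.0-fold higher number from compound 1 to compound 2 (0.30 log units; that floor lies within the scatter), changes the group on the triple-bonded carbon and reaches only the assay's limit (the limit of > 100000 nM in this assay, at which 1 of the 3 values shown sits). Compound 4 `CCCCC#Cc1cn(C/C=C/CN2C(=O)c3ccccc3C2=O)c(=O)[nH]c1=O` differs from compound 3 by hydrogen in place of methyl on a saturated chain carbon, four bonds along the chain from a triple-bonded carbon, a smaller change on the same chain. With no shown step of this kind, no shift beyond the scatter is expected, so the estimated step is a 1.1-fold higher number from compound 3 to compound 4 (0.05 log units; within the scatter). Compound 4 is therefore expected to give about 45000 nM, between 20000 nM and 100000 nM.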

Compound 4, half-maximal inhibitory concentration: 35000 nM
For compound 4 the middle estimate is 1.3-fold (0.11 log units) above the measured one; low and high end bracket the measured number.
By their numbers in this assay, from the lowest: compounds 4, 3 and 1 (each within the scatter of the next). At a limit, above all of these: compound 2.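

On this chain, hydrogen in place of methyl, four bonds along the chain from a triple-bonded carbon, gives a 1.1-fold lower number from compound 3 to compound 4 (0.06 log units; within the scatter) in this assay. Among the compounds shown here, this is the first measured step at this place on the chain, and it stays within the scatter. For the compounds shown here, the only earlier step put 4-pentylphenyl in place of octyl on a triple-bonded carbon.

As far as these compounds go, whether an amine or a carboxylic acid at this place would behave the same stays open, as does the effect of a much shorter chain. No measurement shown speaks to the reason for this step.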